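The source may hold more compounds than are shown below. What is called first, only, known or untested is meant among the compounds shown, and "the series" means these compounds.

In a functional assay on A549 cells (Homo sapiens) for cytotoxicity, read by MTT assay, with a stated time of 48 h (on this read-out higher numbers stand for weaker inhibition and lower numbers for stronger inhibition), two related compounds have been measured so far. Compound 1 `COc1cc([C@@H]2C[C@]2(CO)C(=O)NCc2ccc(C)cc2)cc(OC)c1OC` gives 10500 nM, while compound 2 `COc1cc([C@H]2C[C@]2(CO)C(=O)Nc2ccccc2Cl)cc(OC)c1OC` gives 36700 nM. Compound 2 therefore holds the higher of the two numbers and is the weaker inhibitor, with a gap to compound 1 that lies beyond the usual scatter. The next compound, compound 3 `COc1cc([C@H]2C[C@]2(CO)C(=O)NCc2ccc(C)cc2)cc(OC)c1OC`, has 4-methylbenzyl in place of 2-chlorophenyl on an amide-type nitrogen. Among the measured compounds shown here, no measured step isolates this change, so the expectation rests on little evidence. Compound 1 also carries 4-methylbenzyl and gives 10500 nM, so a moderate step towards a lower number in this assay is expected, though one that may only just clear the scatter. The estimated change is a 2.3-fold lower number from compound 2 to compound 3 (0.36 log units; beyond the scatter). For compound 3, the expected value is 16000 nM, within an estimated range of 6000 nM to 42000 nM.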

Compound 3, half-maximal inhibitory concentration: 60700 nM
Compound 3: middle estimate off by 3.8-fold (0.58 log units), on the low side; measured number above the stated range.
By their numbers in this assay, from the lowest: compound 1; then compounds 2 and 3 (each within the scatter of the next).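

In this assay, 4-methylbenzyl in place of 2-chlorophenyl on the amide-type nitrogen gives a 1.7-fold higher number from compound 2 to compound 3 (0.22 log units; within the scatter), so with the configuration as drawn in these two compounds, this change does not separate them. The same 4-methylbenzyl group also appears on both sides of a 5.8-fold higher number from compound 1 to compound 3 (0.76 log units; beyond the scatter), a modest step but one beyond the scatter, so that group alone does not fix the number in this assay. The drawn configuration at the stereocentre on a saturated ring carbon therefore matters here, the basis being: the fact that compounds 1 and 3 differ only in the configuration as drawn

As far as these compounds go, it remains open whether the same stereocentre step would appear with 2-chlorophenyl on that nitrogen. Also open, from the compounds shown here alone, is how a pyridine ring or a longer alkyl chain at this position would read in this assay.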